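This account rests on a few compounds, and the source may have more. Where it says the series, first, only, none or still open, it means among the compounds named here.

Series in a functional assay on PC-12 cells (Rattus norvegicus) for cytotoxicity, read by MTT assay, with stated times of 3 h and 2 h, tested at 0.1 uM; a higher number here means a stronger effect of the compound at the concentration tested, a lower number a weaker effect:
compound 1 `O=C(CCCCC1CCSS1)NCc1cn(CCCCCOc2ccc3ccc(=O)oc3c2)nn1` gives 46.3%
compound 2 `CC(=O)c1cc2ccc(OCCCCCn3cc(CNC(=O)CCCCC4CCSS4)nn3)cc2oc1=O` gives 28.9%
compound 3 `CCOC(=O)c1cc2ccc(OCCCCCn3cc(CNC(=O)CCCCC4CCSS4)nn3)cc2oc1=O` gives 34.4%

Compound 3 stands second highest of the three numbers: its gap to compound 2 is within the scatter, a number 5.5 percentage points higher from compound 2 to compound 3 (within the scatter), while compound 1 lies higher beyond the scatter, a number 11.9 percentage points lower from compound 1 to compound 3 (beyond the scatter). Compound 4 `O=C(CCCCC1CCSS1)NCc1cn(CCCCCOc2ccc3cc(-c4ccccc4)c(=O)oc3c2)nn1` differs from compound 3 by phenyl in place of ethoxycarbonyl on an aromatic carbon. Among the compounds with values here, no measured step exchanges one substituent at this position for another; the measured steps show only that either substituent lowered the read-out relative to hydrogen, a number 17.4 percentage points lower from compound 1 to compound 2 (beyond the scatter) and a number 11.9 percentage points lower from compound 1 to compound 3 (beyond the scatter), and that the two substituted compounds lie together. For compound 4 the expected step is small and uncertain in direction, a number 3.6 percentage points higher from compound 3 to compound 4 (within the scatter), with a wide range to cover either case. Compound 4 is therefore estimated at 38%, from 22% to 55%.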

Compound 4, a percentage reported as activity, at one concentration (the size of the read-out at that concentration, not a potency): 35.5%
The estimate for compound 4 lay 2.5 percentage points above the measured number; measured number inside the range.
By their numbers in this assay, from the lowest: compounds 2, 3 and 4 (each within the scatter of the next); then compound 1.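

In this assay, phenyl at this aromatic carbon gives a read-out that stays with those of the two carbonyl-bearing substituents (a number 1.1 percentage points higher from compound 3 to compound 4 (within the scatter); a number 6.6 percentage points higher from compound 2 to compound 4 (within the scatter)), yet remains under the unsubstituted parent (a number 10.8 percentage points lower from compound 1 to compound 4 (beyond the scatter)). The lower read-out relative to hydrogen therefore holds across all three substituents, including one with 0 hydrogen-bond acceptors and only carbon atoms. No evidence is available on what underlies this. Still open, from the compounds shown here alone, is whether an amine or a carboxylic acid at this position would stay with compounds 2, 3 and 4 or return towards compound 1.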